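Fluoro for chloro: working notes on the series

The source may report more compounds than this note shows. Statements on the series, on what has been measured and on what is new or still open speak of the compounds shown alone.

In a functional assay on MCF7 cells (Homo sapiens) for cytotoxicity, read by MTT assay, with a stated time of 48 h (on this read-out higher numbers stand for weaker inhibition and lower numbers for stronger inhibition), compound 2 `C/C(=N/NC(=S)Nc1ccc(Cl)cc1)c1ccccn1` gives 8.49 nM, the highest number of the three measured. Compound 1 `C/C(=N\NC(=S)Nc1ccccc1I)c1ccccn1` gives 4.1 nM and compound 3 `C/C(=N/NC(=S)Nc1ccccc1I)c1ccccn1` gives 4.1 nM. Compound 4 `C/C(=N/NC(=S)Nc1ccc(F)cc1)c1ccccn1` carries fluoro in place of chloro on an aromatic carbon, para to a large group: fluoro in place of chloro on an aromatic carbon. Within the data shown here, the only measured step, no change at the digits printed from compound 1 to compound 3 (within the scatter), is a change of configuration as drawn, so it gives no size for this exchange. The expectation therefore rests on compound 2 at 8.49 nM, and no clear direction is expected in this assay. The estimated step is a 1.1-fold higher number from compound 2 to compound 4 (0.03 log units; within the scatter), none beyond the scatter being expected. For compound 4 the estimate is 9 nM, with an expected range of 3.5 nM to 25 nM.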

Compound 4, half-maximal inhibitory concentration: 1.2 nM
Compound 4: the middle estimate sits 7.5-fold (0.88 log units) above what was measured; measured number below the stated range.
By their numbers in this assay, from the lowest: compound 4; then compounds 1 and 3 (each within the scatter of the next); then compound 2.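

At this position, on an aromatic carbon para to a large group, the exchange of one halogen for another is not silent: in this assay fluoro in place of chloro gives a 7.1-fold lower number from compound 2 to compound 4 (0.85 log units; beyond the scatter). Among these compounds, the earlier compounds offered only a change of configuration as drawn, so this is the first size for an exchange of groups. Nothing shown accounts for this step.

Open, going by these compounds, is whether bromo, methoxy or an amine at the same position would extend this step or reverse it. Also open, on these data alone, is whether the same exchange gives a step of this size on the core of compound 1.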